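This account rests on a few compounds, and the source may have more. Where it says the series, first, only, none or still open, it means among the compounds named here.

Measured in a functional assay (aorta) with Rattus norvegicus as the target; a higher number here means that more compound is needed for the effect, a lower number that less compound is needed:
- compound 1 `CC(C)NC1=NS(=O)(=O)c2cc(Cl)ccc2N1`: 36.3 uM
- compound 2 `CCNC1=NS(=O)(=O)c2cc(F)ccc2N1`: > 300 uM
- compound 3 `CCCNC1=NS(=O)(=O)c2cc(F)ccc2N1`: 166 uM

Compound 3 gives 166 uM, the higher of the two actual numbers, and compound 1 gives 36.3 uM, a gap beyond the scatter. Compound 2 reports only a limit, > 300 uM.

Compound 4 `CC(C)C(C)NC1=NS(=O)(=O)c2cc(F)ccc2N1` carries 1,2-dimethylpropyl in place of propyl on an amine nitrogen. Going by the values given here, one measured step bears on this change: an at least 1.8-fold lower number from compound 2 to compound 3 (0.25 log units; that floor lies within the scatter). Its floor lies within the scatter, so it gives only a weak pointer towards a lower number in this assay as the chain grows. The expected change is a 4.2-fold lower number from compound 3 to compound 4 (0.62 log units; beyond the scatter). Compound 4 is estimated at 40 uM, with an expected range of 10 uM to 150 uM.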

Compound 4, concentration for half-maximal effect: 26.4 uM
Compound 4: the middle estimate sits 1.5-fold (0.18 log units) above what was measured; the range from low to high includes it.
By their numbers in this assay, from the lowest: compounds 4 and 1 (each within the scatter of the next); then compound 3. At a limit, above all of these: compound 2.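

In this assay, the substituent on this amine nitrogen now gives a step beyond the scatter, with 1,2-dimethylpropyl in place of propyl: a 6.3-fold lower number from compound 3 to compound 4 (0.80 log units; beyond the scatter). The earlier step at this position had a floor within the scatter, whereas this floor lies beyond it: an at least 11-fold lower number from compound 2 to compound 4 (1.05 log units; beyond the scatter). Compound 2 stands at a limit, so this second step gives only a floor: the limit of > 300 uM in this assay, at which 1 of the 4 values shown sits.

From the compounds shown here alone, whether a straight pentyl chain or a cyclopentyl ring on this nitrogen would give a similar number remains open. Branching and added carbons therefore cannot yet be told apart.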